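The compounds below may be only part of what the source reports. "The series", "measured", "known", "first", "only" and "open" are said of these compounds alone.

For the measured compounds named here, compound 2 `N#Cc1ccc(S(=O)(=O)N2C/C(=C\c3cccc(F)c3)C(=O)/C(=C/c3cccc(F)c3)C2)cc1` is one of two compounds measured in an ADME assay on L02 cells (Homo sapiens) for cytotoxicity, read by MTT assay, with a stated time of 24 h (a higher number here means a weaker inhibitor, a lower number a stronger inhibitor), where compound 2 gives 15500 nM. Compound 1 `O=C1/C(=C/c2cccc(F)c2)CN(S(=O)(=O)c2ccc(Cl)cc2)C/C1=C\c1cccc(F)c1` carries chloro where compound 2 carries cyano; in this assay compound 1 gives 15700 nM. Going by the values given here, the only measured step, a 1.0-fold lower number from compound 1 to compound 2 (0.01 log units; within the scatter), is flat. Compound 3 `CC(=O)Nc1ccc(S(=O)(=O)N2C/C(=C\c3cccc(F)c3)C(=O)/C(=C/c3cccc(F)c3)C2)cc1` differs from compound 2 by acetamido in place of cyano on an aromatic carbon. Among the compounds with values here, the single step that bears on this change was within the scatter, so no step beyond the scatter is expected in this assay for compound 3, giving an estimated no change at the digits printed from compound 2 to compound 3 (within the scatter). Compound 3 is therefore expected near 15500 nM, in a range from 7000 nM to 35000 nM.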

Compound 3, half-maximal inhibitory concentration: 17500 nM
Compound 3: middle estimate off by 1.1-fold (0.05 log units), on the low side; the measured number falls inside the stated range.
By their numbers in this assay, from the lowest: compounds 2, 1 and 3 (each within the scatter of the next).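

Acetamido, the larger of the groups and the one bringing a hydrogen-bond donor, gives a 1.1-fold higher number from compound 2 to compound 3 (0.05 log units; within the scatter) and a 1.1-fold higher number from compound 1 to compound 3 (0.05 log units; within the scatter) in this assay. Chloro, cyano and acetamido on this aromatic carbon therefore cannot be told apart in this assay, so the flat result now extends beyond a single exchange. Nothing available explains why these groups read alike. Going by these compounds, whether an amine, a carboxylic acid or a longer chain at this place would shift the number stays open. The compounds shown also leave open whether this flatness holds with changes elsewhere on the shared core.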